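The source may report more compounds than this note shows. Statements on the series, on what has been measured and on what is new or still open speak of the compounds shown alone.

Compounds measured in a functional assay on A549 cells (Homo sapiens) for antiproliferative activity, read by MTT assay, with a stated time of 24 h; a lower number here means a stronger inhibitor, a higher number a weaker inhibitor:
compound 1 `COc1ccc(C(=O)/C=C/c2cc(-c3cc(OC)c(OC)c(OC)c3)n3nc(-c4ccccc4)cc3n2)cc1` gives 14600 nM
compound 2 `COc1cc(C(=O)/C=C/c2cc(-c3cc(OC)c(OC)c(OC)c3)n3nc(-c4ccccc4)cc3n2)cc(OC)c1OC` gives 20500 nM
compound 3 `COc1ccc(-c2cc(/C=C/C(=O)c3cc(OC)c(OC)c(OC)c3)nc3cc(-c4ccccc4)nn23)cc1OC` gives 7200 nM

Compound 1 holds the second highest of the three numbers. Compound 2 lies within the scatter of compound 1, while compound 3 gives a lower number, a gap beyond the scatter. The measured steps are a 1.4-fold higher number from compound 1 to compound 2 (0.15 log units; within the scatter) and a 2.8-fold lower number from compound 2 to compound 3 (0.45 log units; beyond the scatter); neither touches the part of the molecule changed here. Compound 4 `COc1cc(-c2cc(C(=O)/C=C/c3ccc(Cl)cc3)nc3cc(-c4ccccc4)nn23)cc(OC)c1OC` differs from compound 1 by (2-(4-chlorophenyl)ethenyl)carbonyl in place of 2-((4-methoxyphenyl)carbonyl)ethenyl on an aromatic carbon. Going by the values given here, no measured step concerns the direction of the enone or a chlorine on the outer ring, and both recorded steps were small. Accordingly no step beyond the scatter is expected. The estimate for compound 4 in this assay is 12000 nM, with a range from 4000 nM to 36000 nM. The expected step is a 1.2-fold lower number from compound 1 to compound 4 (0.09 log units; within the scatter).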

Compound 4, half-maximal inhibitory concentration: 23800 nM
Compound 4: middle estimate off by 2.0-fold (0.30 log units), on the low side; the measured number falls inside the stated range.
By their numbers in this assay, from the lowest: compound 3; then compounds 1, 2 and 4 (each within the scatter of the next).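

At this aromatic carbon next to the ring nitrogen, in this assay, placing the carbonyl before the ethenyl and exchanging 4-methoxyphenyl for 4-chlorophenyl together gives a 1.6-fold higher number from compound 1 to compound 4 (0.21 log units; within the scatter) so this double change produces no shift beyond the scatter. The two alterations arrive as one step, and their separate contributions cannot be read from it. Nothing available explains the result.

Open, going by these compounds, are the reversed linker with 4-methoxyphenyl kept and the original linker carrying 4-chlorophenyl. Also open, on these data alone, is a dimethylamino group or a carboxylic acid on the outer ring.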